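Chromone triazole series: benzyl substitution and cytotoxicity

The source may hold more compounds than are shown below. What is called first, only, known or untested is meant among the compounds shown, and "the series" means these compounds.

Two compounds carry measured numbers. Compound 1 `Cc1ccc(Cn2cc(COc3ccc4c(=O)ccoc4c3)nn2)cc1` is the weaker of the pair: in a functional assay on A549 cells (Homo sapiens) for cytotoxicity, read by MTT assay, with a stated time of 48 h (a lower number here means a stronger inhibitor, a higher number a weaker inhibitor), compound 1 gives 50700 nM. Compound 2 `O=c1ccoc2cc(OCc3cn(Cc4ccc(Cl)cc4Cl)nn3)ccc12` gives 5260 nM in this assay, the lowest of the two numbers on hand, with compound 1 as its nearest neighbour. Among the compounds with values here, the single measured step, a 9.6-fold lower number from compound 1 to compound 2 (0.98 log units; beyond the scatter), is the only comparison available. It bears on the change at hand: both alter the group on the saturated chain carbon bound to an aromatic nitrogen.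

Compound 3 `O=c1ccoc2cc(OCc3cn(Cc4cccc(Cl)c4)nn3)ccc12` keeps the shared core of compound 2 unchanged and differs only in 3-chlorophenyl in place of 2,4-dichlorophenyl on a saturated chain carbon bound to an aromatic nitrogen. The measured step exchanged one benzyl substitution pattern for another and moved the number downward; the present step exchanges that pattern again, this time for 3-chlorophenyl. Within the data shown here, no measured pair shows how 3-chlorophenyl compares with 2,4-dichlorophenyl, so the expectation rests on compound 1 and compound 2 alone. Compound 3 is expected to give about 15000 nM in this assay, between 5000 nM and 45000 nM. The step implied by this estimate, a 2.9-fold higher number from compound 2 to compound 3 (0.46 log units; beyond the scatter), is expected to be a modest rise.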

Compound 3, half-maximal inhibitory concentration: 13700 nM
Compound 3: middle estimate off by 1.1-fold (0.04 log units), on the high side; the measured number falls inside the stated range.
By their numbers in this assay, from the lowest: compound 2; then compound 3; then compound 1.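

At the position on a saturated chain carbon bound to an aromatic nitrogen, 3-chlorophenyl in place of 2,4-dichlorophenyl gives a 2.6-fold higher number from compound 2 to compound 3 (0.42 log units; beyond the scatter) in this assay, while 3-chlorophenyl in place of 4-methylphenyl gives a 3.7-fold lower number from compound 1 to compound 3 (0.57 log units; beyond the scatter). Both steps lie beyond the scatter, so the position now shows a three-level order rather than the single contrast available before, with the 3-chlorophenyl compound in the middle and the two chlorine-bearing compounds both lower than the 4-methylphenyl compound. No measurement on hand accounts for this order.

The step from 2,4-dichlorophenyl to 3-chlorophenyl changes the number of chlorines and their placement together, so the compounds shown cannot separate these two contributions to the rise. As far as these compounds go, it also remains open how this order would extend to an unsubstituted phenyl, to a phenyl carrying an amine or a carboxylic acid, or to a longer chain in place of the single saturated carbon, since all three compounds keep a chlorine- or methyl-bearing phenyl on that carbon.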